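This account rests on a few compounds, and the source may have more. Where it says the series, first, only, none or still open, it means among the compounds named here.

Measured compounds, in a functional assay on WM 266-4 cells (Homo sapiens) for antiproliferative activity, read by MTT assay, with a stated time of 24 h; on this read-out lower numbers stand for stronger inhibition of growth and higher numbers for weaker inhibition of growth:
compound 1 `COc1ccc(C2=NN(C(=O)c3ccc(Cl)nc3)C(c3ccc(Br)cc3)C2)cc1`, where compound 1 gives 7130 nM
compound 2 `COc1ccc(C2=NN(C(=O)c3ccc(C)nc3Cl)C(c3ccc(Br)cc3)C2)cc1`, where compound 2 gives 8470 nM
compound 3 `O=C(c1ccc(Cl)nc1)N1N=C(c2ccc(Cl)cc2)CC1c1ccc(Cl)cc1`, where compound 3 gives 9890 nM

All three values lie within the scatter of one another, so no order among them is read. Compound 1 and compound 2 differ in one place: 2-chloro-6-methylpyridin-3-yl in place of 6-chloropyridin-3-yl on a carbonyl carbon. The step is a 1.2-fold higher number from compound 1 to compound 2 (0.07 log units; within the scatter), within the scatter. Compound 3 and compound 1 differ in more than one place; the difference between the two cores is not broken down here. Compound 4 `Cc1ccc(C(=O)N2N=C(c3ccc(Cl)cc3)CC2c2ccc(Cl)cc2)c(Cl)n1` is not yet measured. It differs from compound 3 by 2-chloro-6-methylpyridin-3-yl in place of 6-chloropyridin-3-yl on a carbonyl carbon, the same change at the same place as that between compound 1 and compound 2. The expected step in this assay is a 1.2-fold higher number from compound 3 to compound 4 (0.07 log units; within the scatter), because the matching step a 1.2-fold higher number from compound 1 to compound 2 (0.07 log units; within the scatter) stayed within the scatter. Compound 4 is therefore estimated at 11500 nM, with a range from 5500 nM to 24000 nM.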

Compound 4, concentration for 50% growth inhibition: 8870 nM
For compound 4 the middle estimate is 1.3-fold (0.11 log units) above the measured one; low and high end bracket the measured number.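

In this assay, 2-chloro-6-methylpyridin-3-yl in place of 6-chloropyridin-3-yl on a carbonyl carbon gives (a 1.1-fold lower number from compound 3 to compound 4 (0.05 log units; within the scatter)), and the same change on the two cores compares as follows: the same change on two cores in this assay, a 1.2-fold higher number (0.07 log units; within the scatter) from compound 1 to compound 2 and a 1.1-fold lower number (0.05 log units; within the scatter) from compound 3 to compound 4, 1.3-fold (0.12 log units) apart, within the scatter of two such steps.
The change therefore carries from the core of compound 1 to the core of compound 3 without a step beyond the scatter on either core, and the two steps do not differ beyond the scatter.
This rests on two pairs in one cell assay, so it shows no opposite direction between the cores and no general rule for the series.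

Open, as far as these compounds go, is whether a different group on the pyridine ring, such as an amine or a carboxylic acid, would give a step beyond the scatter. Also open, from the compounds shown here alone, is whether such a step would carry from one core to the other.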